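The source may hold more compounds than are shown below. What is called first, only, known or untested is meant among the compounds shown, and "the series" means these compounds.

Compound 1 `CCCSc1nc(N/N=C/c2ccccc2Cl)c2nnn(Cc3ccccc3)c2n1` is one of three analogues sharing a core; its companions are compound 2 `CCCSc1nc(N/N=C/c2cc(OC)c(OC)c(OC)c2)c2nnn(Cc3ccccc3)c2n1` and compound 3 `C#CCSc1nc(N/N=C/c2cc(OC)c(OC)c(OC)c2)c2nnn(Cc3ccccc3)c2n1`. In a functional assay on MGC-803 cells (Homo sapiens) for antiproliferative activity, read by MTT assay, with a stated time of 72 h (on this read-out lower numbers stand for stronger inhibition and higher numbers for weaker inhibition), compound 1 gives 10900 nM, the highest of the three numbers. Compound 2 gives 9410 nM, within the scatter of compound 1, while compound 3 gives 4670 nM, beyond it. For the measured compounds named here, the one measured step, a 2.0-fold lower number from compound 2 to compound 3 (0.30 log units; within the scatter), concerns the chain on the sulfur, not the aryl group. Compound 4 `CCCSc1nc(N/N=C/c2c(O)ccc3ccccc23)c2nnn(Cc3ccccc3)c2n1` differs from compound 1 by 2-hydroxynaphthalen-1-yl in place of 2-chlorophenyl on a carbon with a double bond to nitrogen. Going by the values given here, no measured step bears on this exchange; the aryl difference between compound 1 and compound 2 stays within the scatter. Compound 4 is therefore expected to show only a modest step, a 1.8-fold lower number from compound 1 to compound 4 (0.26 log units; within the scatter), in this assay, estimated at 6000 nM with a range from 2000 nM to 18000 nM.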

Compound 4, half-maximal inhibitory concentration: 3710 nM
Compound 4: the middle estimate sits 1.6-fold (0.21 log units) above what was measured; low and high end bracket the measured number.
By their numbers in this assay, from the lowest: compounds 4, 3, 2 and 1 (each within the scatter of the next, the first and the last beyond it).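

In this assay the aryl group on the carbon with a double bond to nitrogen now gives a step beyond the scatter, a 2.9-fold lower number from compound 1 to compound 4 (0.47 log units; beyond the scatter), whereas the aryl difference between compound 1 and compound 2 stayed within it. The exchange brings in a second six-membered aromatic ring and a hydrogen-bond donor together, so their shares in the step cannot be separated. Nothing given here explains the step. As far as these compounds go, it remains open whether plain naphthalen-1-yl or 2-hydroxyphenyl would give the same number, and whether an amine in place of the hydroxyl would keep it.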